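A few compounds are considered here, and "the series" means these few. Any claim that something is new, unique, unknown or untested is made for them only; others in the source may bear on it.

Measured so far:
- compound 1, `CCCCN(CCCC)Cc1cn(CC(O)COC(=O)NCc2ccccc2)nn1`: 42%
- compound 2, `CC(C)CCN(C)Cc1cn(CC(O)COC(=O)NCc2ccccc2)nn1`: 26%
- compound 3, `CCCCN(CCCC)Cc1cn(CC(O)COC(=O)C2CCCCC2)nn1`: 12%

All three were run in an assay on nucleic acid for inhibition of Nucleic Acid, read by fluorescence, tested at 100 uM; a higher number here means more inhibition at the concentration tested (going by the name of the read-out), a lower number less inhibition. Compound 1 gives the highest of the three numbers, and its two steps to the others are both beyond the scatter. From compound 1 to compound 2 the change is isopentyl(methyl)amino in place of dibutylamino on a saturated chain carbon bound to an aromatic carbon; the step in this assay is a number 16 percentage points lower from compound 1 to compound 2 (beyond the scatter). From compound 1 to compound 3 the change is cyclohexyl in place of benzylamino on a carbonyl carbon; the step is a number 30 percentage points lower from compound 1 to compound 3 (beyond the scatter). Compound 3 stands lowest of the three, with compound 2 nearest and compound 1 furthest, both gaps beyond the scatter.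

Compound 4, `CC(C)CCN(C)Cc1cn(CC(O)COC(=O)C2CCCCC2)nn1`, is not yet measured. It differs from compound 3 by isopentyl(methyl)amino in place of dibutylamino on a saturated chain carbon bound to an aromatic carbon. Within the data shown here, this is the same change as the one from compound 1 to compound 2, made on the core of compound 3 rather than the core of compound 1; the two cores differ by cyclohexyl in place of benzylamino on a carbonyl carbon.

The expectation for compound 4 rests on one prior instance of this change, namely a number 16 percentage points lower from compound 1 to compound 2 (beyond the scatter), together with the low starting point of compound 3 at 12%. A step of the same sign is expected, but the read-out cannot fall far below the bottom of the scale, so the expected step from compound 3 to compound 4 is a number 9 percentage points lower from compound 3 to compound 4 (within the scatter). Compound 4 is expected to give about 3% in this assay, with a likely range from -8% to 15%.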

Compound 4, a percentage reported as inhibition, at one concentration (the size of the read-out at that concentration, not a potency): 0%
Compound 4: the middle estimate sits 3 percentage points above what was measured; the range from low to high includes it.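

In this assay, isopentyl(methyl)amino in place of dibutylamino lowers the number again on the core of compound 3, a number 12 percentage points lower from compound 3 to compound 4 (beyond the scatter), and the two instances agree: the same change on two cores in this assay, a number 16 percentage points lower (beyond the scatter) from compound 1 to compound 2 and a number 12 percentage points lower (beyond the scatter) from compound 3 to compound 4, 4 percentage points apart, within the scatter of two such steps. Cyclohexyl in place of benzylamino on a carbonyl carbon also carries over to the core of compound 2, a number 26 percentage points lower from compound 2 to compound 4 (beyond the scatter), with the same agreement: the same change on two cores in this assay, a number 30 percentage points lower (beyond the scatter) from compound 1 to compound 3 and a number 26 percentage points lower (beyond the scatter) from compound 2 to compound 4, 4 percentage points apart, within the scatter of two such steps. Across these four compounds each change therefore transfers with a similar size on the two cores, but this rests on a single set of four compounds at one tested concentration, and it does not explain why either change lowers the number; compound 4, at 0%, also stands at the bottom of the scale, where any larger drop on this core could not show.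

From the compounds shown here alone, it remains open whether a longer chain on the amine, such as dihexylamino, or a cyclic amine, such as piperidine or morpholine, would raise the number above that of compound 1. Going by these compounds, it is equally open how a phenethylamino group or an unsubstituted phenyl on the carbonyl carbon would compare with benzylamino and cyclohexyl.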